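The compounds below may be only part of what the source reports. "The series", "measured", "known", "first", "only" and "open" are said of these compounds alone.

Measured so far:
- compound 1, `CCOC(=O)C1=C(C)NC(COC)=C(C(=O)OC)C1c1ccccc1[N+](=O)[O-]`: 790 nM
- compound 2, `CCOC(=O)C1=C(C)NC(CO)=C(C(=O)OCC)C1c1cccc([N+](=O)[O-])c1`: 45 nM
- compound 3, `COC(=O)C1=C(C)NC(C)=C(C(=O)OCc2cc([N+](=O)[O-])cc([N+](=O)[O-])c2)C1c1cccc([N+](=O)[O-])c1`: 40 nM

All three were tested in a functional assay on HEK293 cells for antagonist activity at Voltage-dependent L-type calcium channel subunit alpha-1D (Rattus norvegicus), read by FLIPR; on this read-out lower numbers stand for stronger inhibition and higher numbers for weaker inhibition. Compound 1 gives 790 nM, compound 2 gives 45 nM, and compound 3 gives 40 nM. Among these three, compound 3 has the lowest number. Its nearest neighbour is compound 2, whose number is only slightly higher, a gap that lies within the scatter of repeated measurements; the two cannot be told apart. Compound 1 stands furthest away, with a clearly higher number, a gap well beyond the scatter.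

The next compound, compound 4, `COC(=O)C1=C(C)NC(C)=C(C(=O)OCCOCc2ccccc2)C1c1cccc([N+](=O)[O-])c1`, has not yet been measured in this assay. It is derived from compound 3 by a single change: (benzyloxy)methyl in place of 3,5-dinitrophenyl on a saturated chain carbon bound to an oxygen next to a carbonyl group

Going by the values given here, no measured pair shows this exact change, so its effect can only be guessed from the spread of ester groups among compounds 2 and 3, whose numbers sit close together. The step expected for a 1.3-fold higher number from compound 3 to compound 4 (0.10 log units; within the scatter) is therefore small, most likely within the scatter, with no clear direction. Compound 4 is estimated at 50 nM, with a range from 15 nM to 160 nM.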

Compound 4, half-maximal inhibitory concentration: 12 nM
Compound 4: the middle estimate sits 4.2-fold (0.62 log units) above what was measured; the measured number lies below the stated range.
By their numbers in this assay, from the lowest: compound 4; then compounds 3 and 2 (each within the scatter of the next); then compound 1.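

In this assay, putting (benzyloxy)methyl in place of 3,5-dinitrophenyl on a saturated chain carbon bound to an oxygen next to a carbonyl group gives a 3.3-fold lower number from compound 3 to compound 4 (0.52 log units; beyond the scatter), which shows that the number responds to what is attached at this place. The earlier compounds shown here differ from one another in more than one place, so they could not show this for a single change. The group that leaves has 12 heavy atoms and 4 hydrogen-bond acceptors and the group that enters has 9 and 1, while each has one six-membered aromatic ring of carbon only, and no measurement here explains why this swap lowers the number.

Going by these compounds, the two nitro groups go, and an ether oxygen and a longer link to the ring arrive, all in the same step, so the share of each in the lower number stays open. How a plain benzyl group or a chain ending in an amine would read at this place also remains an open question.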